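The source may hold more compounds than are shown below. What is called first, only, known or untested is meant among the compounds shown, and "the series" means these compounds.

Working notes, thromboxane synthase series. Compound 1 `COCCn1nc(-c2cccnc2)c2ccccc2c1=O` gives 55% in an assay on isolated protein (Oryctolagus cuniculus) with Thromboxane-A synthase (Homo sapiens) as the target, tested at 1 uM; on this read-out lower numbers stand for less inhibition and higher numbers for more inhibition at the one concentration tested (going by the name of the read-out). Compound 2 `CC(=O)OCCn1nc(-c2cccnc2)c2ccccc2c1=O` gives 32% in this assay, and compound 3 `O=C(c1cccs1)n1nc(-c2cccnc2)c2ccccc2c1=O` gives 37%. Among the three numbers compound 3 stands second highest; its nearest neighbour is compound 2, where a number 5 percentage points higher from compound 2 to compound 3 (within the scatter), and its furthest is compound 1, where a number 18 percentage points lower from compound 1 to compound 3 (beyond the scatter). The remaining step, a number 23 percentage points lower from compound 1 to compound 2 (beyond the scatter), concerns a change on the side chain oxygen rather than on the ring nitrogen.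

Within the data shown here, compound 4 `O=c1c2ccccc2c(-c2cccnc2)nn1CCSc1nccs1` is the next member to be tested. 2-((1,3-thiazol-2-yl)sulfanyl)ethyl in place of (thiophen-2-yl)carbonyl on an aromatic nitrogen The steps that bear on this change are the two that alter the group on the same aromatic nitrogen: a number 18 percentage points lower from compound 1 to compound 3 (beyond the scatter) and a number 5 percentage points higher from compound 2 to compound 3 (within the scatter). The two-carbon chains measured so far gave numbers spanning from compound 2 to compound 1, and compound 3 lies within the scatter of compound 2. The new group in compound 4 is again a two-carbon chain ending in a five-membered aromatic ring, so no step beyond the scatter is expected from compound 3, with a slight lean upward given a number 18 percentage points lower from compound 1 to compound 3 (beyond the scatter). Compound 4 is therefore expected to give about 42% in this assay, within 22% to 62%. The expected step is a number 5 percentage points higher from compound 3 to compound 4 (within the scatter).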

Compound 4, a percentage reported as inhibition, at one concentration (the size of the read-out at that concentration, not a potency): 97%
Compound 4: middle estimate off by 55 percentage points, on the low side; the whole stated range lies below it.
By their numbers in this assay, from the lowest: compounds 2 and 3 (each within the scatter of the next); then compound 1; then compound 4.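

Among these compounds, on the aromatic nitrogen of the shared core, 2-((1,3-thiazol-2-yl)sulfanyl)ethyl in place of (thiophen-2-yl)carbonyl gives a number 60 percentage points higher from compound 3 to compound 4 (beyond the scatter) in this assay and shows that this position can hold far more inhibition at the one concentration tested than the earlier compounds indicated. The end of the chain counts as well, with (1,3-thiazol-2-yl)sulfanyl in place of acetoxy giving a number 65 percentage points higher from compound 2 to compound 4 (beyond the scatter) and the same group in place of methoxy giving a number 42 percentage points higher from compound 1 to compound 4 (beyond the scatter) on an otherwise unchanged side chain. Nothing at hand bears on why this group gives such a high number.

The compounds shown leave open whether the step belongs to the sulfur link or to the 1,3-thiazol-2-yl ring, as the two enter together in a single group. Also open, from the compounds shown here alone, is how the number responds to a phenylsulfanyl or 1,3-thiazol-2-yloxy group at the chain end, to an amine there, or to a longer chain carrying the same (1,3-thiazol-2-yl)sulfanyl group.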